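Aryl replacement at the fused core: furan-2-yl for difluorophenyl

The source may hold more compounds than are shown below. What is called first, only, known or untested is meant among the compounds shown, and "the series" means these compounds.

Compound 2 `COc1ccc(S(=O)(=O)N2CCc3cccc(-c4ccc(F)c(F)c4)c32)cc1` carries a 3,4-difluorophenyl on the shared core. In a functional assay on HT-29 cells (Homo sapiens) for inhibition, with a stated time of 72 h (on this read-out lower numbers stand for stronger inhibition and higher numbers for weaker inhibition), compound 2 gives 57 nM, the lowest of the three numbers. Going by the values given here, compound 1 `COc1ccc(S(=O)(=O)N2CCc3cccc(-c4ccc(F)cc4)c32)cc1` gives 85.5 nM; the only single-point step here, a 1.5-fold lower number from compound 1 to compound 2 (0.18 log units; within the scatter), lies within the scatter. Compound 3 `COc1ccc(S(=O)(=O)N2CCc3cccc(-c4cc(OC)c(OC)c(OC)c4)c32)cc1` gives 5100 nM, far weaker. Compound 4 `COc1ccc(S(=O)(=O)N2CCc3cccc(-c4ccco4)c32)cc1` differs from compound 2 as follows: furan-2-yl in place of 3,4-difluorophenyl on an aromatic carbon. Among the compounds with values here, no measured step covers an exchange of the whole aryl group for a five-membered heteroaryl; the values of compound 2 and compound 3 only show that the group at this place matters greatly. Compound 4 is therefore expected to give 250 nM, with a range from 60 nM to 1200 nM. This expectation corresponds to a 4.4-fold higher number from compound 2 to compound 4 (0.64 log units; beyond the scatter), a weakening beyond the scatter but far from the level of compound 3.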

Compound 4, half-maximal inhibitory concentration: 62.5 nM
Estimate against measurement, compound 4: 4.0-fold (0.60 log units) above; low and high end bracket the measured number.
By their numbers in this assay, from the lowest: compounds 2, 4 and 1 (each within the scatter of the next); then compound 3.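

In this assay, a 1.1-fold higher number from compound 2 to compound 4 (0.04 log units; within the scatter) and a 1.4-fold lower number from compound 1 to compound 4 (0.14 log units; within the scatter) both lie within the scatter, so furan-2-yl at this aromatic carbon matches both fluorinated phenyl groups. The group here therefore need not be a six-membered aromatic ring of carbon only, and a smaller five-membered aromatic ring with a hetero atom is accepted. Nothing available explains this match. Still open, on these data alone, is whether other five-membered heteroaryl groups, such as thiophen-2-yl or imidazolyl, behave like furan-2-yl. Also open, as far as these compounds go, is how a non-aromatic group, such as morpholine or a simple methyl, would read at this place.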